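Replacing Methyl with 3-Methylphenyl on a Sulfonamide

The source may hold more compounds than are shown below. What is called first, only, known or untested is meant among the compounds shown, and "the series" means these compounds.

Compound 1, `Oc1cccc2cc(-c3ccccc3)ccc12`, gives 20% in an assay for binding affinity to 17-beta-hydroxysteroid dehydrogenase type 2 (Homo sapiens), with a stated time of 20 min, tested at 1 uM; on this read-out lower numbers stand for less inhibition and higher numbers for more inhibition at the one concentration tested (going by the name of the read-out).
Compound 2, `O=[N+]([O-])c1ccc(-c2ccc3c(O)cccc3c2)cc1`, gives 13% in this assay.
Compound 3, `CS(=O)(=O)Nc1ccc(-c2ccc(CO)cc2)cc1`, gives < 10% in this assay, which is a limit of the assay and not a number.

Compound 3 thus stands at the limit of < 10% in this assay, at which 1 of the 3 values shown sits. Compound 4, `Cc1cccc(S(=O)(=O)Nc2ccc(-c3ccc(CO)cc3)cc2)c1`, differs from it by 3-methylphenyl in place of methyl on a sulfonyl sulfur. Among the compounds with values here, the only measured step, a number 7 percentage points lower from compound 1 to compound 2 (within the scatter), concerns a different change on a different core and gives no guide here; no measured step bears on this change. With compound 3 sitting at the limit, nothing beyond the scatter can be expected in either direction. Compound 4 is therefore estimated at 12%, between 5% and 28%, and the expected step of a number at least 2 percentage points higher from compound 3 to compound 4 (that floor lies within the scatter) stays within the scatter.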

Compound 4, a percentage reported as inhibition, at one concentration (the size of the read-out at that concentration, not a potency): 12%
Compound 4: the middle estimate sits on the measured number at the digits printed; the measured number falls inside the stated range.
By their numbers in this assay, from the lowest: compounds 4, 2 and 1 (each within the scatter of the next). At a limit, below all of these: compound 3.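

Putting 3-methylphenyl in place of methyl on the sulfonyl sulfur gives, in this assay, a number at least 2 percentage points higher from compound 3 to compound 4 (that floor lies within the scatter). This shows that this position takes an added aromatic ring and still gives a readable number, though a low one. Compound 3 stands at a limit of the assay and not at a number, so only the floor of this step is known: the limit of < 10% in this assay, at which 1 of the 4 values shown sits.

On these data alone, how an amine or a longer carbon chain on the sulfonyl sulfur would read remains open. So does whether plain phenyl there would read like 3-methylphenyl.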